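Pyridin-2-yl to Pyridin-3-yl: Expected Growth Inhibition Unchanged

The compounds below may be only part of what the source reports. "The series", "measured", "known", "first", "only" and "open" are said of these compounds alone.

Compound 1 `Cc1cc(=O)oc2cc(Sc3cccc(Cl)n3)ccc12`: 2110 nM
Compound 2 `Cc1cc(=O)oc2cc(SCc3ccccn3)ccc12`: > 35200 nM

In a functional assay on A549 cells (Homo sapiens) for antiproliferative activity, read by sulforhodamine B assay, with a stated time of 72 h (on this read-out higher numbers stand for weaker inhibition of growth and lower numbers for stronger inhibition of growth), compound 1 gives 2110 nM. Compound 2 gives only a limit of the assay, > 35200 nM, and therefore stands at the limit of > 35200 nM in this assay, at which 1 of the 2 values shown sits. Compound 3 `Cc1cc(=O)oc2cc(SCc3cccnc3)ccc12` differs from compound 2 by pyridin-3-yl in place of pyridin-2-yl on a saturated chain carbon bound to a sulfur. For the measured compounds named here, no measured pair here shows what such a change does, so the step is expected to stay within the scatter, in no particular direction. Compound 3 is therefore estimated at 40000 nM, with a range from 10000 nM to 150000 nM. The expected step is a step that the limit leaves unreadable from compound 2 to compound 3, most likely again reported only as a limit.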

Compound 3, concentration for 50% growth inhibition: > 35200 nM
Compound 3 ended at the assay's limit; the forecaster's own chance of this, stated with the estimate: 70%; the middle value lies beyond the limit too.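

In this assay, compound 2 and compound 3 both give only a limit, so no step between them can be read: the limit of > 35200 nM in this assay, at which 2 of the 3 values shown sit.

As far as these compounds go, whether pyridin-2-yl and pyridin-3-yl differ at all in their effect on growth stays open.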